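Carboxy for hydroxymethyl: expected cytotoxicity step

A few compounds are considered here, and "the series" means these few. Any claim that something is new, unique, unknown or untested is made for them only; others in the source may bear on it.

In an ADME assay on TZM cells (Homo sapiens) for cytotoxicity, read by XTT assay, with a stated time of 4 days (on this read-out lower numbers stand for higher toxicity in this test and higher numbers for lower toxicity in this test), compound 3 (`Cc1cc(/C=C/C#N)cc(C)c1Oc1cc(Nc2ccc(C#N)cc2)c(N)cc1CO`) gives 16300 nM, and compound 1 (`Cc1cc(CCC#N)cc(C)c1Oc1cc(Nc2ccc(C#N)cc2)c(N)cc1C(=O)O`) gives 14300 nM. These two values lie within the scatter of each other. Compound 2 (`Cc1cc(/C=C/C#N)cc(C)c1Oc1cc(Nc2ccc(C#N)cc2)c(N)cc1[N+](=O)[O-]`) gives > 24400 nM, which is a limit of the assay and not a number.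

The change under consideration leads to compound 4 (`Cc1cc(/C=C/C#N)cc(C)c1Oc1cc(Nc2ccc(C#N)cc2)c(N)cc1C(=O)O`): carboxy in place of hydroxymethyl on an aromatic carbon. In words, this is carboxy in place of hydroxymethyl on an aromatic carbon, para to a (4-cyanophenyl)amino group.

Among the measured compounds shown here, only one measured step bears directly on this aromatic carbon: an at least 1.4-fold lower number from compound 2 to compound 3 (0.17 log units; that floor lies within the scatter). Going by these compounds, that step starts from the limit of > 24400 nM in this assay, at which 1 of the 3 values shown sits, so its full size remains open. Compound 1 also carries the carboxy group, and its value of 14300 nM offers a second reference for compound 4. With both points in view, no step beyond the scatter is expected in this assay, in either direction. The expected step is a 1.0-fold lower number from compound 3 to compound 4 (0.01 log units; within the scatter). Compound 4 is estimated at 16000 nM, with an expected range from 8500 nM to 29000 nM.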

Compound 4, half-maximal cytotoxic concentration: 14900 nM
Beside the measured number, compound 4's estimate is 1.1-fold (0.03 log units) above it; the range from low to high includes it.
By their numbers in this assay, from the lowest: compounds 1, 4 and 3 (each within the scatter of the next). At a limit, above all of these: compound 2.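

In this assay, carboxy and hydroxymethyl on this aromatic carbon, para to a (4-cyanophenyl)amino group, read alike, giving a 1.1-fold lower number from compound 3 to compound 4 (0.04 log units; within the scatter). Among the compounds shown here, with the carboxy held constant, compound 4 also gives the first one-place comparison of the 2-cyanoethenyl and 2-cyanoethyl groups, and these too read alike, with a 1.0-fold higher number from compound 1 to compound 4 (0.02 log units; within the scatter). The comparison with nitro gives an at least 1.6-fold lower number from compound 2 to compound 4 (0.21 log units; that floor lies within the scatter), which is only a floor, as compound 2 stands at a limit of the assay and not at a number: the limit of > 24400 nM in this assay, at which 1 of the 4 values shown sits.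

The compounds shown leave open whether an aminomethyl group, a primary carboxamide or a methyl ester on this aromatic carbon would stay within the same narrow band of values as hydroxymethyl and carboxy. They also leave open whether a longer chain in place of the 2-cyanoethenyl group would read the same as the 2-cyanoethyl group does, and how far the value of compound 2 lies beyond its limit.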